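Amino for hydrogen on the aryl ring of compound 1

The source may hold more compounds than are shown below. What is called first, only, known or untested is meant among the compounds shown, and "the series" means these compounds.

The series rests on a shared core carrying an arylamino group. Compound 1 `Cc1nc(Nc2ccccc2)c2cc[nH]c2n1` gives 550000000 nM in a functional assay on the whole organism for inhibition, with Nicotiana tabacum as the target; on this read-out higher numbers stand for weaker inhibition and lower numbers for stronger inhibition. Compound 2 `Cc1nc(Nc2ccc(C#N)cc2)c2cc[nH]c2n1`, which differs in one place, gives 501000000 nM in this assay. Going by the values given here, of the two numbers, that of compound 1 is not separated from that of compound 2 beyond the scatter: the single step, a 1.1-fold lower number from compound 1 to compound 2 (0.04 log units; within the scatter), tells that adding a cyano group to the aryl ring left this assay essentially unchanged.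

Compound 3 `Cc1nc(Nc2cccc(N)c2)c2cc[nH]c2n1` is not yet measured. Relative to compound 1 the change is amino in place of hydrogen on an aromatic carbon. Among the compounds with values here, no measured step involves an amino group or this place on the ring, so the only step that bears on it is the indirect one from compound 1 to compound 2, which was within the scatter. On that basis no step beyond the scatter is expected in this assay for compound 3, in either direction.

The number expected for compound 3 in this assay is therefore 500000000 nM, with a range from 250000000 nM to 1100000000 nM, an estimated step of a 1.1-fold lower number from compound 1 to compound 3 (0.04 log units; within the scatter).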

Compound 3, half-maximal inhibitory concentration: 38900000 nM
Estimate against measurement, compound 3: 13-fold (1.11 log units) above; measured number below the stated range.
By their numbers in this assay, from the lowest: compound 3; then compounds 2 and 1 (each within the scatter of the next).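

In this assay, going by these compounds alone, amino in place of hydrogen on an aromatic carbon, meta to a large group, gives the first step beyond the scatter (a 14-fold lower number from compound 1 to compound 3 (1.15 log units; beyond the scatter)), so the aryl ring of compound 1 does respond to substitution. The earlier step (a 1.1-fold lower number from compound 1 to compound 2 (0.04 log units; within the scatter)) lay within the scatter, but it differs from this one in both the group and its place on the ring, so the contrast cannot be assigned to either difference alone. No available evidence accounts for the size of the new step.

The compounds shown leave open whether the stronger inhibition belongs to the amino group itself or to this place on the ring, since no compound shown carries amino at the place held by the cyano group of compound 2 or a different group at the place held by amino in compound 3. Also open, going by these compounds, is whether a hydroxyl group, a methylamino group or an acetamido group at that same place would keep the step seen with amino.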